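This account rests on a few compounds, and the source may have more. Where it says the series, first, only, none or still open, it means among the compounds named here.

Measured to date:
- compound 1, `Cc1ncc(-c2nc(C(F)(F)F)sc2N2CCN(C(=O)Cn3cnc4cccnc43)[C@H](C)C2)cn1`: 3.6 nM
- compound 2, `CCOc1ncc(-c2nc(C(F)(F)F)sc2N2CCN(C(=O)Cn3cnc4ccccc43)[C@H](C)C2)cn1`: 2 nM
- compound 3, `Cc1ncc(-c2nc(C(F)(F)F)sc2N2CCN(C(=O)Cn3nc(C)nc3C)[C@H](C)C2)cn1`: 19 nM

In a functional assay on CHO-K1 cells for antagonist activity at C-X-C chemokine receptor type 3 (Homo sapiens), read by FLIPR, with a stated time of 10 min (on this read-out higher numbers stand for weaker inhibition and lower numbers for stronger inhibition), compound 3 gives the highest of the three numbers; compound 1 sits closest to it and compound 2 furthest. Going by the values given here, the one single-point step measured so far is a 5.3-fold higher number from compound 1 to compound 3 (0.72 log units; beyond the scatter), a change on the saturated chain carbon bound to the carbonyl carbon. Among the compounds with values here, compounds 1 and 2 differ at the aromatic-ring end as well as on that chain, so their two values show only that both lie well under compound 3, and no step between them is counted.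

Compound 4, `Cc1nc(C)n(CC(=O)N2CCN(c3sc(C(F)(F)F)nc3-c3ccc(C(F)(F)F)nc3)C[C@H]2C)n1`, differs from compound 3 as 6-(trifluoromethyl)pyridin-3-yl in place of 2-methylpyrimidin-5-yl on an aromatic carbon. Within the data shown here, no measured step touches this position, so nothing bears directly on its size or direction. The expectation for compound 4 in this assay is therefore a number near that of compound 3, with a wide range to either side, as a 1.3-fold lower number from compound 3 to compound 4 (0.10 log units; within the scatter). The estimate for compound 4 is 15 nM, between 4 nM and 60 nM.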

Compound 4, half-maximal inhibitory concentration: 4.2 nM
For compound 4 the middle estimate is 3.6-fold (0.55 log units) above the measured one, and the stated range covers the measured number.
By their numbers in this assay, from the lowest: compounds 2, 1 and 4 (each within the scatter of the next, the first and the last beyond it); then compound 3.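

In this assay the aromatic carbon next to the ring nitrogen is now shown to affect the number: 6-(trifluoromethyl)pyridin-3-yl in place of 2-methylpyrimidin-5-yl gives a 4.5-fold lower number from compound 3 to compound 4 (0.66 log units; beyond the scatter) with the group on the saturated chain held constant. Going by these compounds alone, earlier, the only readable single-point change lay on that chain, in a 5.3-fold higher number from compound 1 to compound 3 (0.72 log units; beyond the scatter) as the one step, so this is the first reading of the aromatic-ring end, and it runs toward a lower number. Nothing measured on these compounds accounts for the step.

This single pair leaves open whether the trifluoromethyl group or the change of ring carries the step, which a 6-methylpyridin-3-yl or a 2-(trifluoromethyl)pyrimidin-5-yl group would separate. Also open, as far as these compounds go, are how an amine or a carboxylic acid on this ring would read, and whether the step holds with the chain group of compound 1.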